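The compounds below may be only part of what the source reports. "The series", "measured", "known", "first", "only" and "open" are said of these compounds alone.

Measured so far:
- compound 1, `Brc1cn2ccnc2c(-c2ccc3ncn(C4CCCCC4)c3c2)n1`, in a functional assay on SR cells (Homo sapiens) for inhibition, read by sulforhodamine B assay, with a stated time of 48 h, tested at 10 uM (on this read-out lower numbers stand for less inhibition and higher numbers for more inhibition at the one concentration tested (going by the name of the read-out)), compound 1 gives 26.8%
- compound 2, `O=Cc1ccc(-c2cn3ccnc3c(-c3ccc4ncn(C5CCCCC5)c4c3)n2)cc1`, in this assay compound 2 gives 47.5%

Compound 2 stands highest of the two measured numbers; compound 1 is the only other point, and the step of a number 20.7 percentage points higher from compound 1 to compound 2 (beyond the scatter) is beyond the scatter, so the two are clearly apart.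

Compound 3, `Fc1ccc(-c2cn3ccnc3c(-c3ccc4ncn(C5CCCCC5)c4c3)n2)cc1`, is the compound still to be measured. It differs from compound 2 in one place: fluoro in place of formyl on an aromatic carbon.

Going by the values given here, only one measured step exists, and it is the one from a bromo to a 4-formylphenyl group, a number 20.7 percentage points higher from compound 1 to compound 2 (beyond the scatter). That step shows that putting a phenyl group in this place raises inhibition, but it says nothing about swapping one group on that phenyl for another. With the phenyl kept and only formyl replaced by fluoro, the expected step is small, likely within the scatter and leaning slightly downward, a number 7.5 percentage points lower from compound 2 to compound 3 (within the scatter). For compound 3 the estimate is 40%, in a range from 22% to 58%.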

Compound 3, a percentage reported as inhibition, at one concentration (the size of the read-out at that concentration, not a potency): 20.4%
Beside the measured number, compound 3's estimate is 19.6 percentage points above it, and the stated range ends above it.
By their numbers in this assay, from the lowest: compounds 3 and 1 (each within the scatter of the next); then compound 2.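

In this assay, the group carried on the added phenyl ring turns out to matter: fluoro in place of formyl gives a number 27.1 percentage points lower from compound 2 to compound 3 (beyond the scatter) and so removes the rise seen earlier. The phenyl ring alone therefore does not account for that rise, since 4-fluorophenyl in place of bromo gives a number 6.4 percentage points lower from compound 1 to compound 3 (within the scatter) and leaves those two compounds indistinguishable in this test. Nothing available here shows why formyl and fluoro differ in this way.

On these data alone, it remains open whether an amine, a carboxylic acid or a methoxy group at the same place on the ring would read like formyl or like fluoro. As far as these compounds go, it is also open whether the carbonyl of formyl is what counts, a question that a ketone or an amide there could address.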